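The source may report more compounds than this note shows. Statements on the series, on what has been measured and on what is new or still open speak of the compounds shown alone.

Of the compounds shown here, two built on one shared core have been tested in a functional assay on HCT-116 cells (Homo sapiens) for antiproliferative activity, read by MTT assay, with a stated time of 48 h; a lower number here means a stronger inhibitor, a higher number a weaker inhibitor. Compound 1 `O=C(/C=C/c1ccc([N+](=O)[O-])cc1)Nc1cc(Sc2ncn[nH]2)c(O)c2ccccc12` gives in this assay only the limit > 100000 nM, which is a boundary of the assay and not a number. Compound 2 `O=C(Nc1cc(Sc2ncn[nH]2)c(O)c2ccccc12)c1ccc([N+](=O)[O-])cc1` likewise gives in this assay only the limit > 100000 nM, again a boundary and not a number. Going by the values given here, compound 2 thus stands at the edge of what this assay reports, a position it shares with the only other known value: the limit of > 100000 nM in this assay, at which 2 of the 2 values shown sit. Compound 3 `O=C(Nc1cc(Sc2ncn[nH]2)c(O)c2ccccc12)c1cccc([N+](=O)[O-])c1` has not been measured yet. It differs from compound 2 in one place: 3-nitrophenyl in place of 4-nitrophenyl on a carbonyl carbon. Among the compounds with values here, no step between two measured compounds exists here, so the size of this change cannot be read from any earlier pair. With both known values sitting at the limit, the expectation for compound 3 is that the step of a number no higher from compound 2 to compound 3 (the limit leaves the size open) stays within the usual scatter, and that this assay will most likely again report only a limit. Compound 3 is estimated at 100000 nM, within a range from 30000 nM to 300000 nM.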

Compound 3, half-maximal inhibitory concentration: 70200 nM
Compound 3: the middle estimate sits 1.4-fold (0.15 log units) above what was measured; the range from low to high includes it.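

In this assay, going by these compounds alone, compound 3 gives 70200 nM, the only value shown so far that is a real number and not a limit of the assay, so with 3-nitrophenyl on this carbonyl carbon the series reaches a measurable reading. The change from 4-nitrophenyl to 3-nitrophenyl gives an at least 1.4-fold lower number from compound 2 to compound 3 (0.15 log units; that floor lies within the scatter), and that floor alone does not separate the two compounds. The true size of this step cannot be read, because one end of it is a limit: the limit of > 100000 nM in this assay, at which 2 of the 3 values shown sit.

The compounds shown leave open how this carbonyl position responds to anything other than a nitrophenyl group, for instance a phenyl ring carrying an amine or a carboxylic acid in place of the nitro group. They also leave open whether any group on the shared core can bring the value in this assay well under that of compound 3, since a single number gives no trend to follow.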